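Replacing 2-nitrophenyl with 4-methoxyphenyl on the shared core

The source may report more compounds than this note shows. Statements on the series, on what has been measured and on what is new or still open speak of the compounds shown alone.

In an ADME assay on A549 cells (Homo sapiens) for cytotoxicity, read by MTT assay, with a stated time of 48 h (a higher number here means a weaker inhibitor of growth, a lower number a stronger inhibitor of growth), compound 1 `O=C(/C=C\c1cccc(O)c1)N1N=C(c2ccncc2)OC1c1c[nH]c2ccccc12` gives > 30 ug/mL, which is a limit and not a number. Compound 2 `O=C(/C=C\c1ccccc1[N+](=O)[O-])N1N=C(c2ccncc2)OC1c1c[nH]c2ccccc12` gives > 30 ug/mL, which is also a limit and not a number. Among the measured compounds shown here, the series so far stands at the limit of > 30 ug/mL in this assay, at which 2 of the 2 values shown sit. For the measured compounds named here, the only measured step, a step that the two limits leave unreadable from compound 1 to compound 2, therefore has no readable size. Compound 3 `COc1ccc(/C=C\C(=O)N2N=C(c3ccncc3)OC2c2c[nH]c3ccccc23)cc1` differs from compound 2 by a single change: 4-methoxyphenyl in place of 2-nitrophenyl on a double-bonded chain carbon bound to a double-bonded chain carbon. That measured step is the only one that bears on this exchange, and it gives no size to carry over. No shift beyond the usual scatter can therefore be expected in this assay, in either direction, and compound 3 will most likely also be reported as a limit. The estimated change is a step that the limit leaves unreadable from compound 2 to compound 3. Compound 3 is expected at 40 ug/mL, with an estimated range from 15 ug/mL to 100 ug/mL.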

Compound 3, concentration for 50% growth inhibition: > 30 ug/mL
Compound 3 ended at the assay's limit; the forecaster's own chance of this, stated with the estimate: 75%; the middle value does not contradict the limit.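

Compound 3 gives > 30 ug/mL in this assay, again a limit and not a number. No step among compound 1, compound 2 and compound 3 can be read: the limit of > 30 ug/mL in this assay, at which 3 of the 3 values shown sit.

Going by these compounds, whether the 3-hydroxyphenyl, 2-nitrophenyl and 4-methoxyphenyl compounds differ from one another in this assay remains open.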